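The compounds below may be only part of what the source reports. "The series", "measured", "known", "first", "only" and "open" are said of these compounds alone.

Measured so far in a functional assay on the whole organism (strain Kunming) with Mus musculus as the target, with a stated time of 0.5 h; on this read-out higher numbers stand for an effect only at larger amounts of compound and lower numbers for an effect already at smaller amounts:
- compound 1 `COc1cc(OC)c(OC)cc1/C=C/COC(=O)/C=C/c1c(OC)ccc(OC)c1OC`: 120 umol/kg
- compound 2 `COc1cc(OC)c(OC)cc1/C=C/COC(=O)/C=C/c1ccccc1C(F)(F)F`: 203 umol/kg

Compound 2 stands within the usual scatter of compound 1, so these two numbers cannot be told apart in this assay. The next compound to be measured is compound 3 `COc1cccc(/C=C/C(=O)OC/C=C/c2cc(OC)c(OC)cc2OC)c1`. It keeps the core of compound 2 and has 3-methoxyphenyl in place of 2-(trifluoromethyl)phenyl on a double-bonded chain carbon bound to a double-bonded chain carbon. Going by the values given here, no measured step shows this exact change. Compound 1 also carries a different group at that place, yet compound 1 gives 120 umol/kg, within the scatter of compound 2. Two compounds are thin evidence, but they suggest little sensitivity to this change. The expected 1.4-fold lower number from compound 2 to compound 3 (0.13 log units; within the scatter) therefore stays within the scatter, with no real change foreseen. For compound 3 the estimated value is 150 umol/kg, with an expected range from 70 umol/kg to 320 umol/kg.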

Compound 3, dose for half-maximal effect: 190 umol/kg
Compound 3: middle estimate off by 1.3-fold (0.10 log units), on the low side; the measured number falls inside the stated range.
By their numbers in this assay, from the lowest: compounds 1, 3 and 2 (each within the scatter of the next).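

In this assay, going by these compounds alone, the direct exchange of 2-(trifluoromethyl)phenyl for 3-methoxyphenyl gives a 1.1-fold lower number from compound 2 to compound 3 (0.03 log units; within the scatter) and so provides the first measured single change at this place, on a double-bonded chain carbon bound to a double-bonded chain carbon. The entering group differs from the leaving one in its atoms, with oxygen in place of fluorine and a hydrogen-bond acceptor added, yet this read-out cannot tell the two compounds apart. No measurement available here explains this lack of a visible difference.

On these data alone, whether this insensitivity extends to quite different groups at this place, such as an amine or a carboxylic acid on the phenyl ring, remains open. The compounds shown also leave open how changes to the other end of the molecule, which compound 2 and compound 3 share, would affect the dose needed.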